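The compounds below may be only part of what the source reports. "The series", "measured", "known", "first", "only" and "open" are said of these compounds alone.

Measured so far in a functional assay on the whole organism with Mus musculus as the target, with a stated time of 30 min; a higher number here means that more compound is needed for the effect, a lower number that less compound is needed:
compound 1, `CC(C)S(=O)(=O)NC1CCCN(S(=O)(=O)c2ccc(F)cc2)C1`, 1 mg/kg
compound 2, `CCC(=O)NC1CCN(S(=O)(=O)c2ccc(F)cc2)CC1`, 0.1 mg/kg
compound 3, `CC(C)S(=O)(=O)NC1CCCN(C(=O)c2ccccc2)C1`, 1 mg/kg

Compound 1 stands level with compound 3 at the digits reported, the two together giving the highest of the three numbers; the gap between them lies within the scatter. Compound 2 is the furthest from compound 1, with a lower number, and that difference lies beyond the scatter.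

Compound 4, `CCC(=O)NCC1CCCN(S(=O)(=O)c2ccc(F)cc2)C1`, has not yet been measured in this assay. It differs from compound 1 in one place: (propanoylamino)methyl in place of (isopropylsulfonyl)amino on a saturated ring carbon. Going by the values given here, no pair of measured compounds shows this change directly, so its size can only be judged from what the three numbers show. Compound 2 gives 0.1 mg/kg, and compound 1 gives 1 mg/kg, a difference beyond the scatter. On that basis a step toward the lower number is expected, of size a 3.3-fold lower number from compound 1 to compound 4 (0.52 log units; beyond the scatter) in this assay, though a result within the scatter of compound 1 cannot be ruled out. For compound 4 the estimate is 0.3 mg/kg, with a range from 0.1 mg/kg to 1.5 mg/kg.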

Compound 4, minimum effective dose: 10 mg/kg
For compound 4 the middle estimate is 33-fold (1.52 log units) below the measured one; measured number outside the range, above it.
By their numbers in this assay, from the lowest: compound 2; then compounds 1 and 3 (each within the scatter of the next); then compound 4.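

On a saturated ring carbon of the six-membered non-aromatic ring, two ring bonds from the ring nitrogen, (propanoylamino)methyl in place of (isopropylsulfonyl)amino gives a 10-fold higher number from compound 1 to compound 4 (1.00 log units; beyond the scatter) in this assay. Going by these compounds alone, this is the first direct reading at this position, and it shows that the group on this carbon matters for the dose required. On the core of compound 1, the (propanoylamino)methyl group brings no gain: more compound is needed with it.

The change alters both the carbonyl-for-sulfonyl unit and the link to the ring, so a propanoylamino group directly on the same carbon, or an (isopropylsulfonyl)aminomethyl group, would be needed to separate the two, while a primary amine or a carboxylic acid there would widen the range tested. Nothing measured in the compounds shown accounts for the size of this step.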